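The source may hold more compounds than are shown below. What is called first, only, known or untested is meant among the compounds shown, and "the series" means these compounds.

Of the compounds shown here, three of a shared core have been measured in a functional assay on ACHN cells (Homo sapiens) for cytotoxicity, read by sulforhodamine B assay, with a stated time of 72 h (a higher number here means a weaker inhibitor of growth, a lower number a stronger inhibitor of growth), each carrying a different group on the carbonyl carbon attached to the ring nitrogen and a different anilide. Compound 1 `CC(=O)N1c2ccccc2CCC1C(=O)Nc1ccccc1O` gives 50700 nM in this assay. Compound 2 `CCCCCCCCC(=O)N1c2ccccc2CCC1C(=O)Nc1ccccc1C(F)(F)F`, which carries an octyl chain on that carbonyl carbon, gives 8330 nM in this assay. Compound 3 `O=C(Nc1cc(C(F)(F)F)cc(C(F)(F)F)c1)C1CCc2ccccc2N1C(=O)c1ccc(Cl)cc1` gives 2570 nM in this assay. Among these three numbers compound 2 stands second highest: its number lies beyond the scatter above that of compound 3 and beyond the scatter below that of compound 1, so compound 2 is weaker than compound 3 and stronger than compound 1.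

Compound 4 `O=C(Nc1ccccc1C(F)(F)F)C1CCc2ccccc2N1C(=O)c1ccc(Cl)cc1` has not yet been measured. It differs from compound 2 in one place, (4-chlorophenyl in place of octyl on a carbonyl carbon), and the same change, cut one bond further out, reads octylcarbonyl to (4-chlorophenyl)carbonyl. Within the data shown here, no single-change step between measured compounds is available to calibrate this change, so the expectation rests on the values alone. Compound 3, which carries the same 4-chlorophenyl group on its carbonyl carbon but a different anilide, gives 2570 nM in this assay. The step from compound 2 to compound 4 is therefore expected to be a moderate move toward a lower number, a 1.9-fold lower number from compound 2 to compound 4 (0.27 log units; within the scatter), though it may fall within the scatter. Compound 4 is estimated to give 4500 nM in this assay, with a range from 1500 nM to 13000 nM.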

Compound 4, concentration for 50% growth inhibition: 824 nM
Compound 4: middle estimate off by 5.5-fold (0.74 log units), on the high side; measured number outside the range, below it.
By their numbers in this assay, from the lowest: compound 4; then compound 3; then compound 2; then compound 1.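

Among these compounds, with the anilide and the shared core held fixed in this assay, placing 4-chlorophenyl instead of octyl on the carbonyl carbon bound to the amide-type nitrogen in a ring gives a 10-fold lower number from compound 2 to compound 4 (1.00 log units; beyond the scatter) as the one single-change step in this set. The earlier compounds shown here differed in both this group and the anilide, so they could not show that a change at this position alone moves the number beyond the scatter. The swap also barely alters the heavy-atom count, with 8 leaving and 7 entering, yet it replaces an open chain with an aromatic ring, although nothing measured here explains why the number falls.

As far as these compounds go, what remains open is whether the shift belongs to the aromatic ring or to its chlorine, a question that a plain phenyl group on the same carbonyl carbon would help to settle. Also open, from the compounds shown here alone, is whether the same step holds with other anilides, for example on going from octyl to 4-chlorophenyl with the anilide of compound 3, or whether a shorter chain such as butyl would sit closer to octyl or to 4-chlorophenyl.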